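The source may hold more compounds than are shown below. What is called first, only, known or untested is meant among the compounds shown, and "the series" means these compounds.

Measured compounds in a functional assay on HOP-62 cells (Homo sapiens) for inhibition, read by sulforhodamine B assay; on this read-out lower numbers stand for stronger inhibition of growth and higher numbers for weaker inhibition of growth:

- compound 1 `Oc1ccc(-c2ccc(-c3ccc(-c4nc5ccccc5[nH]4)cc3)cc2)cc1`: 47200 nM
- compound 2 `CN(C)c1ccc(-c2ccc(-c3ccc(-c4nc5ccccc5[nH]4)cc3)cc2)cc1`: 100000 nM
- compound 3 `COc1ccc(-c2ccc(-c3ccc(-c4nc5ccccc5[nH]4)cc3)cc2)cc1OC`: 4200 nM

Compound 3 stands lowest of the three numbers in this assay. Its nearest neighbour is compound 1, as the step of an 11-fold lower number from compound 1 to compound 3 (1.05 log units; beyond the scatter) shows; the furthest is compound 2, with a 24-fold lower number from compound 2 to compound 3 (1.38 log units; beyond the scatter). Between the two weaker compounds the gap is only a 2.1-fold higher number from compound 1 to compound 2 (0.33 log units; beyond the scatter). All three measured steps change the substituent on the terminal phenyl at the far end of the shared core, and they leave the fused ring system untouched.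

Compound 4 `COc1ccc(-c2ccc(-c3ccc(-c4nc5c(O)cccc5[nH]4)cc3)cc2)cc1OC` differs from compound 3 in a different place: hydroxy in place of hydrogen on an aromatic carbon. For the measured compounds named here, the change is on a ring of the fused system, not on the terminal phenyl, so no measured step bears directly on it. The step from compound 1 to compound 2 is the only one that involves a hydroxy, and it sits at the other end of the molecule; it gives no direct guide here. With nothing in the series that speaks to a substituent on the fused rings, the expectation is a step of no more than the scatter, a 1.1-fold higher number from compound 3 to compound 4 (0.03 log units; within the scatter), with a wide range to reflect the lack of a precedent. For compound 4 in this assay the estimate is 4500 nM, expected to lie between 1500 nM and 15000 nM.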

Compound 4, concentration for 50% growth inhibition: 2210 nM
Compound 4: middle estimate off by 2.0-fold (0.31 log units), on the high side; the measured number falls inside the stated range.
By their numbers in this assay, from the lowest: compounds 4 and 3 (each within the scatter of the next); then compound 1; then compound 2.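

In this assay, the difference from 1H-benzimidazol-2-yl to 4-hydroxy-1H-benzimidazol-2-yl gives a 1.9-fold lower number from compound 3 to compound 4 (0.28 log units; within the scatter), so this hydroxy on the fused system of two rings does not separate the two compounds on this read-out. For the compounds shown here, this is the first measured change away from the terminal phenyl, and it stands apart from the steps at that far end, such as an 11-fold lower number from compound 1 to compound 3 (1.05 log units; beyond the scatter) and a 24-fold lower number from compound 2 to compound 3 (1.38 log units; beyond the scatter), which are printed as beyond the scatter. No supporting data are available to explain why the hydroxy leaves the result within the scatter.

From the compounds shown here alone, the series has one substituent at this position, so whether a carboxylic acid, a fluorine or a longer chain on the same aromatic carbon would also stay within the scatter remains open. Also open, going by these compounds, is whether the same hydroxy would give a comparable step on the 4-hydroxyphenyl or 4-(dimethylamino)phenyl compounds, compound 1 and compound 2, since so far it has been read only with the 3,4-dimethoxyphenyl group at the far end.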